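Replacing a sulfanyl imidazole with a piperidinylmethyl chain

The source may report more compounds than this note shows. Statements on the series, on what has been measured and on what is new or still open speak of the compounds shown alone.

Measured compounds:
Compound 1, `Cc1c(C)c2c(c(N)c1N)CC(C)(C)O2`: > 50 mg/kg
Compound 2, `Cc1c(C)c2c(c(C)c1N)CC(C)(CSc1nccn1C)O2`: 37.1 mg/kg
Compound 3, `Cc1c(C)c2c(c(C)c1N)CC(C)(CN1CCC(c3ccccc3)CC1)O2`: 10.4 mg/kg

Of the compounds shown here, three on the shared core have been tested in a functional assay on the whole organism with Mus musculus as the target; a higher number here means that more compound is needed for the effect, a lower number that less compound is needed. For compound 1 the result is a limit of the assay, > 50 mg/kg, not a number (the limit of > 50 mg/kg in this assay, at which 1 of the 3 values shown sits). Of the two numbers that were obtained, compound 2 holds the highest with 37.1 mg/kg; the nearest is compound 3 with 10.4 mg/kg, a difference that lies beyond the usual scatter.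

Compound 4, `Cc1c(C)c2c(c(C)c1N)CC(C)(CCN1CCCCC1)O2`, has not yet been measured in this assay. It differs from compound 2 in one place: (piperidin-1-yl)methyl in place of (1-methyl-1H-imidazol-2-yl)sulfanyl on a saturated chain carbon bound to a saturated ring carbon.

Among the measured compounds shown here, no measured pair follows this exact change, so the size of the step is open. Since compound 3, which carries a different chain on the same carbon, gives 10.4 mg/kg, a lower number than compound 2 appears reachable within this series. Compound 4 is therefore expected to need less compound than compound 2, with an estimated step of a 2.5-fold lower number from compound 2 to compound 4 (0.39 log units; beyond the scatter). The estimate for compound 4 in this assay is 15 mg/kg, within a range from 6 mg/kg to 40 mg/kg.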

Compound 4, dose for 50% inhibition: 18.4 mg/kg
Compound 4: middle estimate off by 1.2-fold (0.09 log units), on the low side; the measured number falls inside the stated range.
By their numbers in this assay, from the lowest: compounds 3, 4 and 2 (each within the scatter of the next, the first and the last beyond it). At a limit, above all of these: compound 1.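

With a 2.0-fold lower number from compound 2 to compound 4 (0.30 log units; within the scatter), this assay now has its first readable step at this position, on a saturated chain carbon bound to a saturated ring carbon. The (piperidin-1-yl)methyl group, with its non-aromatic six-membered ring, can take the place of the (1-methyl-1H-imidazol-2-yl)sulfanyl group, which has the same count of heavy atoms, and the two numbers stay within the scatter of each other. The sulfur link and the aromatic five-membered ring are therefore not needed at this position for a number of this size in this assay.

On these data alone, what a morpholine ring, an open-chain dimethylamino group or a carboxylic acid would give on this carbon remains open. Nothing in the results at hand accounts for the size of the step.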